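The source may report more compounds than this note shows. Statements on the series, on what has been measured and on what is new or still open speak of the compounds shown alone.

Compound 1 `CC1CCN(c2cc(C(F)(F)F)ccc2CNC(=O)C(C)c2ccc(NS(C)(=O)=O)c(F)c2)CC1` is the reference point. In an assay on CHO cells for antagonist activity at transient receptor potential cation channel subfamily V member 1 (Homo sapiens), read by FLIPR (a higher number here means a weaker inhibitor, a lower number a stronger inhibitor), compound 1 gives 0.9 nM, the second highest of the three numbers in hand. Compound 3 `CC(C(=O)NCc1ccc(C(F)(F)F)cc1OC1CCCCC1)c1ccc(NS(C)(=O)=O)c(F)c1` gives 0.7 nM, and the step of a 1.3-fold lower number from compound 1 to compound 3 (0.11 log units; within the scatter) stays within the scatter. Compound 2 `CC(C(=O)NCc1ccc(C(F)(F)F)cc1N1CCN(c2ccccc2)CC1)c1ccc(NS(C)(=O)=O)c(F)c1` gives 2 nM, so the step of a 2.2-fold higher number from compound 1 to compound 2 (0.35 log units; beyond the scatter) is modest. Compound 4 `CC(C(=O)NCc1ccc(C(F)(F)F)cc1SC1CCCCC1)c1ccc(NS(C)(=O)=O)c(F)c1` differs from compound 1 in one place: cyclohexylsulfanyl in place of 4-methylpiperidin-1-yl on an aromatic carbon. The closest guide is the cyclohexyloxy change from compound 1 to compound 3, which hardly moved the number, and the step of a 2.9-fold lower number from compound 2 to compound 3 (0.46 log units; beyond the scatter) points the same way, toward a slightly lower number. Little movement beyond the scatter is therefore expected, a 1.1-fold lower number from compound 1 to compound 4 (0.05 log units; within the scatter). Compound 4 is expected to give 0.8 nM, most likely between 0.35 nM and 2 nM.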

Compound 4, inhibition constant: 0.5 nM
Beside the measured number, compound 4's estimate is 1.6-fold (0.20 log units) above it, within the range that was stated.
By their numbers in this assay, from the lowest: compounds 4, 3 and 1 (each within the scatter of the next); then compound 2.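

In this assay, a sulfur link holds up at this position: the step of a 1.4-fold lower number from compound 3 to compound 4 (0.15 log units; within the scatter) leaves cyclohexylsulfanyl level with cyclohexyloxy, and the step of a 1.8-fold lower number from compound 1 to compound 4 (0.26 log units; within the scatter) leaves it level with 4-methylpiperidin-1-yl. Among the compounds shown here, only the step of a 4.0-fold lower number from compound 2 to compound 4 (0.60 log units; beyond the scatter) clears the scatter, so 4-phenylpiperazin-1-yl is the one group here that stands apart from the rest. Nothing available explains these numbers. Still open, on these data alone, is how a much smaller group, such as methoxy or a primary amine, would behave at this position, and whether a longer chain on the sulfur would keep the number this low.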